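The source may hold more compounds than are shown below. What is called first, only, known or untested is meant among the compounds shown, and "the series" means these compounds.

Notes on the series so far, with two compounds read in an ADME assay on the whole organism (Rattus norvegicus) for metabolic stability, at a dose of 1 mg/kg by the intravenous route; on this read-out higher numbers stand for a longer-lived compound and lower numbers for a shorter-lived compound. Compound 1 (`O=C(c1cn[nH]c1)N1CCC(C(=O)N2N=CCC2c2ccccc2)CC1`) gives 0.417 h, the lower of the two numbers available. Compound 2 (`Cc1nnc(N2CCC(C(=O)N3N=CC[C@H]3c3cc(F)cc(F)c3)CC2)o1`) gives 1.7 h, and the gap between these two values lies beyond the usual scatter. Among the compounds with values here, no pair of measured compounds differs in one place only, so no measured step speaks directly to the next change.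

That change leads from compound 1 to compound 3 (`O=C(c1cocn1)N1CCC(C(=O)N2N=CCC2c2ccccc2)CC1`), and it reads (1,3-oxazol-4-yl in place of 1H-pyrazol-4-yl on a carbonyl carbon). In words, it is 1,3-oxazol-4-yl in place of 1H-pyrazol-4-yl on a carbonyl carbon, with the rest of the structure unchanged. Within the data shown here, the data hold no measured precedent for this swap, so neither direction is supported and the working expectation in this assay is no shift beyond the scatter. The estimated step, a 1.2-fold higher number from compound 1 to compound 3 (0.08 log units; within the scatter), is expected to stay inside that scatter. For compound 3 the expected half-life is 0.5 h, with an estimated range of 0.25 h to 1 h.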

Compound 3, half-life: 0.2 h
Compound 3: the middle estimate sits 2.5-fold (0.40 log units) above what was measured, outside the stated range (below it).
By their numbers in this assay, from the lowest: compound 3; then compound 1; then compound 2.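

Within the data shown here, at the carbonyl carbon whose other neighbour is an amide-type nitrogen in a ring, 1,3-oxazol-4-yl in place of 1H-pyrazol-4-yl gives the first one-place comparison in this assay (a 2.1-fold lower number from compound 1 to compound 3 (0.32 log units; beyond the scatter)), so the aromatic ring at this position is not neutral for this read-out, and the oxazole is the shorter-lived of the two. The swap keeps the count of 5 heavy atoms, the five-membered aromatic ring with 2 hetero atoms and the absence of a net charge, while 1 hydrogen-bond donor and 1 hydrogen-bond acceptor become 0 hydrogen-bond donors and 2 hydrogen-bond acceptors, and this single pair cannot show which of these differences, if any, accounts for the step. No supporting measurement is available to explain the shift.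

Open, on these data alone, is whether other groups on this carbonyl carbon, such as 1,3-thiazol-4-yl or a simple amine, would give a longer or shorter half-life than either ring seen here. Also open, as far as these compounds go, is whether the same swap would give a step of similar size and direction on the core of compound 2, which differs from compound 1 and compound 3 in more than one place.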